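The source may hold more compounds than are shown below. What is called first, only, known or untested is meant among the compounds shown, and "the series" means these compounds.

Within the data shown here, compound 2, with structure `CC1CCN(C(=O)CCSc2nc3cc(Cl)ccc3o2)C1`, is the only compound here that carries a number. In an ADME assay on microsomes from liver (Mus musculus) for metabolic stability, read by LC-MS, using NADPH, with a stated time of 45 min, tested at 0.5 uM (on this read-out higher numbers stand for fast clearance and lower numbers for slow clearance), compound 2 gives 90.7 mL/min/g. A second compound, compound 1, with structure `O=C(CCSc1nc2cc(Cl)ccc2o1)NC1CCCC1`, belongs to the same series, yet in this assay compound 1 gives "not determined" (no result reported), so there is nothing to set beside compound 2 and no comparison can be drawn between the two.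

Compound 3, with structure `CC1CCCN1C(=O)CCSc1nc2cc(Cl)ccc2o1`, has not yet been measured. It is built from the same atoms as compound 2, joined differently: 2-methylpyrrolidin-1-yl in place of 3-methylpyrrolidin-1-yl on a carbonyl carbon. Among the measured compounds shown here, with no measured pair of this kind available, the size of such a step in this assay cannot be read from the data. The expectation is therefore that compound 3 will sit close to compound 2, with a step from compound 2 to compound 3 of a 1.0-fold lower number from compound 2 to compound 3 (0.00 log units; within the scatter) expected, that is, none beyond the usual scatter. For compound 3 the expected value in this assay is 90 mL/min/g, with a likely range from 45 mL/min/g to 180 mL/min/g, to be checked against the measurement.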

Compound 3, intrinsic clearance in a liver preparation (reported as CLH), per the amount of preparation that the assay uses: 98 mL/min/g
Compound 3: the middle estimate sits 1.1-fold (0.04 log units) below what was measured; measured number inside the range.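

Among these compounds, this is the first measured pair, and it shows that shifting the methyl group around the ring, with the atoms otherwise unchanged, makes no visible difference here: in this assay, 2-methylpyrrolidin-1-yl in place of 3-methylpyrrolidin-1-yl on a carbonyl carbon gives a 1.1-fold higher number from compound 2 to compound 3 (0.03 log units; within the scatter). At this position, then, the two methylpyrrolidin-1-yl groups cannot be told apart on this read-out, and the pair stands at one level of clearance. Nothing measured here bears on why the two match, so no explanation can be offered.

Still open, from the compounds shown here alone, is whether a group of a different kind on the same carbonyl carbon, such as a morpholine, a piperidine or an open-chain diethylamino group, would move the number beyond the usual scatter, since a swap between two methylpyrrolidin-1-yl groups says little about larger changes. Equally open, going by these compounds, is how the number responds to changes elsewhere in the molecule, for instance a nitrile in place of the chlorine on the shared core, or a longer chain between the sulfur and the carbonyl.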